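Neopentyl to pentyl on the shared core

The compounds below may be only part of what the source reports. "The series", "measured", "known", "first", "only" and "open" are said of these compounds alone.

In a physicochemical assay for lipophilicity, using the shake flask method, in phosphate buffer, with a stated time of 1 h (on this read-out higher numbers stand for higher lipophilicity and lower numbers for lower lipophilicity), compound 1 `CC(C)(C)C(=O)OC[C@H]1O[C@@H](n2cnc3c(N)ncnc32)[C@@H](O)[C@@H]1O` gives 1.63, compound 2 `CC(C)(C)CC(=O)OC[C@H]1O[C@@H](n2cnc3c(N)ncnc32)[C@@H](O)[C@@H]1O` gives 1.7 and compound 3 `CC(C)CC(=O)OC[C@H]1O[C@@H](n2cnc3c(N)ncnc32)[C@@H](O)[C@@H]1O` gives 1.39. Compound 2 thus stands within the scatter of compound 1 and beyond the scatter of compound 3.

Compound 4 `CCCCCC(=O)OC[C@H]1O[C@@H](n2cnc3c(N)ncnc32)[C@@H](O)[C@@H]1O` differs from compound 2 in one place, with neopentyl becoming pentyl: butyl in place of tert-butyl on a saturated chain carbon bound to a carbonyl carbon. The two have the same atoms, joined differently. Going by the values given here, no compound with a straight chain has been measured, so no measured step shows this exact change.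

Among the compounds with values here, the closest precedent is isobutyl in place of tert-butyl, again the same atoms joined differently, which gives a number 0.24 log units lower from compound 1 to compound 3 (within the scatter). Neopentyl in place of tert-butyl gives a number 0.07 log units higher from compound 1 to compound 2 (within the scatter). Only hydrogen in place of methyl goes beyond the scatter, with a number 0.31 log units lower from compound 2 to compound 3 (beyond the scatter), and that step changes the atoms rather than rearranging them.

On these steps, no change beyond the scatter is expected in this assay, and they fix no firm direction for a straight chain. The step expected is a number 0.10 log units higher from compound 2 to compound 4 (within the scatter). For compound 4 the estimated value is 1.8, with an expected range of 1.5 to 2.1.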

Compound 4, partition coefficient: 1.78
Estimate against measurement, compound 4: 0.02 log units above; low and high end bracket the measured number.
By their numbers in this assay, from the lowest: compounds 3, 1, 2 and 4 (each within the scatter of the next, the first and the last beyond it).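

In this assay, straightening the chain at this position, on a saturated chain carbon bound to a carbonyl carbon, gives a number 0.08 log units higher from compound 2 to compound 4 (within the scatter), so butyl in place of tert-butyl leaves compound 2 and compound 4 indistinguishable on this read-out. The same holds when the whole acyl chain is compared, with a number 0.15 log units higher from compound 1 to compound 4 (within the scatter). Only butyl in place of isopropyl on that same carbon goes further, with a number 0.39 log units higher from compound 3 to compound 4 (beyond the scatter), so within these compounds the straight chain separates from the shorter isobutyl ester but not from the two branched esters with tert-butyl groups, and no measurement shown offers an explanation for this.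

The compounds shown leave open whether a longer chain such as hexyl or octyl at this position would carry the number beyond the scatter of compound 4, or whether a cyclohexyl ring would behave like the straight chain or the branched ones. They also leave open how far an amine or a carboxylic acid on the chain would pull the number from that of compound 4.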